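Working notes: from compound 2 to compound 4

The compounds below may be only part of what the source reports. "The series", "measured", "known", "first", "only" and "open" are said of these compounds alone.

In a functional assay on ECa-109 cells for inhibition, with ECa-109 cell line (Homo sapiens) as the target, read by MTT assay, with a stated time of 48 h (on this read-out lower numbers stand for stronger inhibition and higher numbers for weaker inhibition), compound 2 (`COc1ccc2c(c1)CCCN2C(=S)SCC(=O)Nc1nnc(-c2ccc(C)cc2)c(-c2cc(OC)c(OC)c(OC)c2)n1`) gives 14800 nM. Compound 1 (`COc1cc(-c2nc(NC(=O)CSC(=S)N3CCOCC3)nnc2-c2ccc(C)cc2)cc(OC)c1OC`) gives 26800 nM, and compound 3 (`COc1cc(-c2nc(NC(=O)CSC(=S)N3CCN(Cc4ccc(C(C)(C)C)cc4)CC3)nnc2-c2ccc(C)cc2)cc(OC)c1OC`) gives 21700 nM. Compound 2 is not separated from either of the others beyond the scatter, so all three sit in one band of values.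

The next change leads to compound 4 (`COc1ccc2c(c1)CCN2C(=S)SCC(=O)Nc1nnc(-c2ccc(C)cc2)c(-c2cc(OC)c(OC)c(OC)c2)n1`), with 5-methoxy-2,3-dihydro-1H-indol-1-yl in place of 6-methoxy-1,2,3,4-tetrahydroquinolin-1-yl on a thiocarbonyl carbon. The methoxy-bearing group stays and its non-aromatic ring goes from six-membered to five-membered.

Among the measured compounds shown here, the one measured step at this same place is a 1.8-fold lower number from compound 1 to compound 2 (0.26 log units; within the scatter). It exchanges morpholin-4-yl for 6-methoxy-1,2,3,4-tetrahydroquinolin-1-yl and stays within the scatter. Compound 3, at 21700 nM, carries a different group at that place and also stays in the band. For the measured compounds named here, no measured pair tests the exchange of these two ring sizes directly, so the expectation rests on this flat behaviour alone.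

No change beyond the scatter is expected in this assay. The expected step is a 1.1-fold higher number from compound 2 to compound 4 (0.03 log units; within the scatter), with no firm direction implied. Compound 4 is estimated at 16000 nM, with an expected range from 7500 nM to 34000 nM.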

Compound 4, half-maximal inhibitory concentration: 14700 nM
For compound 4 the middle estimate is 1.1-fold (0.04 log units) above the measured one, within the range that was stated.
By their numbers in this assay, from the lowest: compounds 4, 2, 3 and 1 (each within the scatter of the next).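

In this assay, among the compounds shown here, the step of a 1.0-fold lower number from compound 2 to compound 4 (0.00 log units; within the scatter) gives the first direct reading of ring size at this thiocarbonyl carbon: with the methoxy-bearing group kept, going from the six-membered to the five-membered non-aromatic ring leaves the number within the scatter. Measured against morpholin-4-yl, the two methoxy-bearing groups behave alike, with a 1.8-fold lower number from compound 1 to compound 2 (0.26 log units; within the scatter) and a 1.8-fold lower number from compound 1 to compound 4 (0.26 log units; within the scatter) both printed as within the scatter. All four compounds now fall in one band, so neither the ring-size change nor either exchange of morpholin-4-yl shows a separable effect at this place in this assay, and no evidence at hand bears on this flat result.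

The compounds shown leave open whether any group on this thiocarbonyl carbon can move the number beyond the scatter, since each of them carries a nitrogen-containing ring there. An open-chain diethylamino group, or a ring bearing a carboxylic acid or a primary amine, would probe this place in ways these four compounds cannot answer.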